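Swapping fluorine for chlorine on a pyridine-ring arylsulfone

The source may hold more compounds than are shown below. What is called first, only, known or untested is meant among the compounds shown, and "the series" means these compounds.

Measured compounds:
compound 1 `COc1ccccc1S(=O)(=O)/C=C/c1ccccc1Cl` 530 nM
compound 2 `COc1ccccc1S(=O)(=O)/C=C/c1ccccn1` 9070 nM
compound 3 `COc1ccccc1S(=O)(=O)/C=C/c1ncccc1F` 877 nM

Of the compounds shown here, three sharing one core have been tested in an assay on U2OS cells for activation of nuclear factor erythroid 2-related factor 2 (Homo sapiens), read by chemiluminescence, with a stated time of 6 h; on this read-out lower numbers stand for an effect already at smaller amounts and higher numbers for an effect only at larger amounts of compound. Compound 3 stands second highest of the three numbers: its nearest neighbour is compound 1, whose value sits within the scatter of it, and its furthest is compound 2, a gap beyond the scatter. The new compound 4 `COc1ccccc1S(=O)(=O)/C=C/c1ncccc1Cl` differs from compound 3 in one place: chloro in place of fluoro on an aromatic carbon.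

Within the data shown here, only one measured step touches this position. Going a 10-fold lower number from compound 2 to compound 3 (1.01 log units; beyond the scatter) shows that a halogen at this carbon matters greatly compared with hydrogen. Among the measured compounds shown here, no step compares chloro with fluoro here; compound 1 carries chloro on a different ring, and its value against compound 3 lies within the scatter, so no direction can be drawn from it. The expectation is therefore a change no larger than the scatter, expressed as a 1.3-fold lower number from compound 3 to compound 4 (0.13 log units; within the scatter). Compound 4 is estimated at 650 nM in this assay, with a range from 250 nM to 1700 nM.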

Compound 4, half-maximal effective concentration: 142 nM
Compound 4: the middle estimate sits 4.6-fold (0.66 log units) above what was measured; measured number outside the range, below it.
By their numbers in this assay, from the lowest: compound 4; then compounds 1 and 3 (each within the scatter of the next); then compound 2.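

In this assay, among these compounds, the earlier compounds showed only that a halogen on this carbon counts for much more than hydrogen; now the choice of halogen proves to matter too, with chloro in place of fluoro giving a further clear gain (a 6.2-fold lower number from compound 3 to compound 4 (0.79 log units; beyond the scatter)). Measured against hydrogen, chloro also gives a larger step (a 64-fold lower number from compound 2 to compound 4 (1.81 log units; beyond the scatter)) than fluoro does (a 10-fold lower number from compound 2 to compound 3 (1.01 log units; beyond the scatter)), so at this carbon the numbers fall from hydrogen to fluoro to chloro. Nothing available explains why chloro and fluoro differ here.

On these data alone, with only these three groups at this carbon, it remains open whether the numbers would fall further with bromo, or whether a methyl or a methoxy group could match chloro. As far as these compounds go, it is also open whether the gain from chloro would hold with a different group on the other ring of the shared core.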